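From phenyl to 4-chlorophenyl: a small step expected

The source may report more compounds than this note shows. Statements on the series, on what has been measured and on what is new or still open speak of the compounds shown alone.

In a functional assay on Caco-2 cells (Homo sapiens) for cytotoxicity, with a stated time of 48 h (a higher number here means a weaker inhibitor, a lower number a stronger inhibitor), compound 2 (`COc1cc(OC)c(C(=O)/C=C/c2ccccc2)c(OC)c1`) gives 5800 nM and so sits level, within the scatter, with compound 1 (`COc1cc(OC)c(C(=O)/C=C/c2ccccc2SC)c(OC)c1`), which gives 8800 nM in the same test. With only these two numbers in hand, neither compound can be called the stronger.

Compound 3 (`COc1cc(OC)c(C(=O)/C=C/c2ccc(Cl)cc2)c(OC)c1`) keeps the core of compound 2 and differs in a single place. It carries chloro in place of hydrogen on an aromatic carbon, para to a large group, which turns phenyl into 4-chlorophenyl (chloro in place of hydrogen on an aromatic carbon).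

Among the measured compounds shown here, the one measured step that bears on this change is hydrogen in place of methylsulfanyl, and with a 1.5-fold lower number from compound 1 to compound 2 (0.18 log units; within the scatter) as the sole guide, nothing beyond the scatter is expected in this assay for compound 3, in either direction. For the measured compounds named here, that guide is a loose one, as it concerns a different group and no measured compound carries chloro.

The expected step is a 1.2-fold lower number from compound 2 to compound 3 (0.06 log units; within the scatter) and it remains an estimate for now. For compound 3 the estimated value is 5000 nM with an expected range from 2000 nM to 12000 nM around it.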

Compound 3, half-maximal inhibitory concentration: 5700 nM
Estimate against measurement, compound 3: 1.1-fold (0.06 log units) below; measured number inside the range.
By their numbers in this assay, from the lowest: compounds 3, 2 and 1 (each within the scatter of the next).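

In this assay, among the compounds shown here, chloro in place of hydrogen on an aromatic carbon, para to a large group, gives a 1.0-fold lower number from compound 2 to compound 3 (0.01 log units; within the scatter) and so offers the first direct reading of this change: compound 3 sits level with compound 2. Replacing the whole 2-(methylsulfanyl)phenyl with 4-chlorophenyl gives a 1.5-fold lower number from compound 1 to compound 3 (0.19 log units; within the scatter) and places all three compounds within the scatter of one another, so none can be called the stronger in this test. No supporting measurement bears on why these numbers stay level.

Among the compounds shown, this place on the ring carries only hydrogen or chloro, so it remains open whether an amine, a carboxylic acid or a longer chain there would move the number beyond the scatter. All three compounds also share the same core, which leaves open whether a clearer difference would appear if the core itself were changed.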